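Moving the Chlorine Around the Benzoyl Ring of Compound 1

This account rests on a few compounds, and the source may have more. Where it says the series, first, only, none or still open, it means among the compounds named here.

Compound 1 `O=C(Nc1ccccc1O)C1CCc2ccccc2N1C(=O)c1ccc(Cl)cc1` is the weakest of the three measured compounds in a functional assay on MDA-MB-231 cells (Homo sapiens) for cytotoxicity, read by sulforhodamine B assay, with a stated time of 72 h (a higher number here means a weaker inhibitor of growth, a lower number a stronger inhibitor of growth), where compound 1 gives 19600 nM. Its nearest neighbour on this scale is compound 2 `O=C(Nc1cc(C(F)(F)F)cc(C(F)(F)F)c1)C1CCc2ccccc2N1C(=O)c1ccc(Cl)cc1`, which in this assay gives 2000 nM; furthest away is compound 3 `O=C(Nc1ccccc1C(F)(F)F)C1CCc2ccccc2N1C(=O)c1ccc(Cl)cc1`, which in this assay gives 533 nM. Among the compounds with values here, the only single-point step that has been measured, a 37-fold lower number from compound 1 to compound 3 (1.57 log units; beyond the scatter), lies at the anilide end of the shared core. Compound 4 `O=C(Nc1ccccc1O)C1CCc2ccccc2N1C(=O)c1cccc(Cl)c1` differs from compound 1 at the other end: 3-chlorophenyl in place of 4-chlorophenyl on a carbonyl carbon. Within the data shown here, no measured step touches the benzoyl group, since all three measured compounds carry the same 4-chlorophenyl on that carbonyl carbon, so the large step from compound 1 to compound 3 offers no guide to the size or direction of this change. In this assay compound 4 is therefore expected to show no change at the digits printed from compound 1 to compound 4 (within the scatter), a step that stays within the scatter. The estimate for compound 4 in this assay is 19600 nM, with a range from 7000 nM to 50000 nM.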

Compound 4, concentration for 50% growth inhibition: 10600 nM
Beside the measured number, compound 4's estimate is 1.8-fold (0.27 log units) above it; low and high end bracket the measured number.
By their numbers in this assay, from the lowest: compound 3; then compound 2; then compounds 4 and 1 (each within the scatter of the next).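

Within the data shown here, this is the first measured step at the benzoyl end of the shared core, and in this assay it stays within the scatter (a 1.8-fold lower number from compound 1 to compound 4 (0.27 log units; within the scatter)). With the hydroxy anilide held fixed, 3-chlorophenyl and 4-chlorophenyl on this carbonyl carbon cannot be told apart in this read-out, unlike the large step at the anilide end (a 37-fold lower number from compound 1 to compound 3 (1.57 log units; beyond the scatter)). No evidence on hand bears on this result.

Going by these compounds, whether the two chlorophenyl groups also match when paired with the trifluoromethyl anilide of compound 3 remains open, as a single pair cannot settle it. Also open, on these data alone, is how this carbonyl carbon would tolerate a different group altogether, such as a pyridine ring, a methoxyphenyl or a longer alkyl chain.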